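Propoxy to Pentylsulfanyl on a Shared Core

A few compounds are considered here, and "the series" means these few. Any claim that something is new, unique, unknown or untested is made for them only; others in the source may bear on it.

Compound 1 `CCCCNc1nc(N)c2nc(O)n(Cc3ccccc3)c2n1` gives 0.1 mg/kg in a functional assay on the whole organism for activation, with Mus musculus as the target; on this read-out lower numbers stand for an effect already at smaller amounts and higher numbers for an effect only at larger amounts of compound. Within the data shown here, compound 2 `CCCOc1nc(N)c2nc(O)n(Cc3ccccc3)c2n1` gives 0.3 mg/kg in this assay, the higher of the two numbers so far, since a 3.0-fold higher number from compound 1 to compound 2 (0.48 log units; beyond the scatter). Compound 3 `CCCCCSc1nc(N)c2nc(O)n(Cc3ccccc3)c2n1` differs from compound 2 in one place: pentylsulfanyl in place of propoxy on an aromatic carbon. Among the measured compounds shown here, no measured step exchanges propoxy for a sulfur-linked chain, so the single known step, butylamino to propoxy, bears on it only loosely and gives no clear direction. Compound 3 is therefore expected to change little in this assay, no change at the digits printed from compound 2 to compound 3 (within the scatter), with an estimate of 0.3 mg/kg between 0.1 mg/kg and 1 mg/kg.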

Compound 3, minimum effective dose: 1 mg/kg
Compound 3: middle estimate off by 3.3-fold (0.52 log units), on the low side; low and high end bracket the measured number.
By their numbers in this assay, from the lowest: compound 1; then compound 2; then compound 3.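

In this assay, this position between two ring nitrogen atoms is sensitive to a sulfur-linked chain: pentylsulfanyl in place of propoxy gives a 3.3-fold higher number from compound 2 to compound 3 (0.52 log units; beyond the scatter), and in place of butylamino it gives a 10-fold higher number from compound 1 to compound 3 (1.00 log units; beyond the scatter). Across these three compounds, the dose needed rises from butylamino through propoxy to pentylsulfanyl.

The step to compound 3 changes the linking atom and the chain at once, so their shares stay unresolved, and a propylsulfanyl or pentyloxy group would separate them. No measured evidence here explains the order of the three compounds.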